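A few compounds are considered here, and "the series" means these few. Any claim that something is new, unique, unknown or untested is made for them only; others in the source may bear on it.

Working notes on the series. The shared core carries a tert-butyl isoxazole amide joined to a piperidine ring, and the three measured compounds differ only in what sits on the amine nitrogen of that ring. Compound 1 `CC(C)(C)c1cc(NC(=O)[C@@H]2CCCCN2C2CCOCC2)no1` gives 74 ug/mL in a physicochemical assay for solubility, read by HPLC, at pH 6.8; on this read-out higher numbers stand for higher solubility and lower numbers for lower solubility. Compound 2 `CC(C)(C)c1cc(NC(=O)[C@@H]2CCCCN2C(=O)c2ccccc2)no1` gives 0.9 ug/mL in this assay, and compound 3 `CC(C)(C)c1cc(NC(=O)[C@@H]2CCCCN2C(=O)C2CCCCC2)no1` gives 6.4 ug/mL in this assay. On these numbers compound 3 stands second of three: a 7.1-fold higher number from compound 2 to compound 3 (0.85 log units; beyond the scatter), while a 12-fold lower number from compound 1 to compound 3 (1.06 log units; beyond the scatter), and the widest gap is seen in that an 82-fold lower number from compound 1 to compound 2 (1.91 log units; beyond the scatter).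

Compound 4 `CC(C)(C)c1cc(NC(=O)[C@@H]2CCCCN2C(=O)CC2CCOCC2)no1` is not yet measured in this assay. Relative to compound 3 the change is (oxan-4-yl)methyl in place of cyclohexyl on a carbonyl carbon. For the measured compounds named here, two measured steps bear on it. The acyl side carrying a saturated carbocycle rather than a phenyl is already on record: a 7.1-fold higher number from compound 2 to compound 3 (0.85 log units; beyond the scatter). Going by the values given here, the only compound bearing an oxane ring on the ring nitrogen, compound 1, holds the highest number, 74 ug/mL, though its step to compound 3 also exchanged the carbonyl and so is not the same change. A modest rise beyond the scatter, not reaching compound 1, is therefore expected: a 3.1-fold higher number from compound 3 to compound 4 (0.49 log units; beyond the scatter). Compound 4 is estimated at 20 ug/mL in this assay, with a range from 8 ug/mL to 50 ug/mL.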

Compound 4, solubility: 52 ug/mL
For compound 4 the middle estimate is 2.6-fold (0.41 log units) below the measured one; measured number above the stated range.
By their numbers in this assay, from the lowest: compound 2; then compound 3; then compounds 4 and 1 (each within the scatter of the next).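

With the rest of compound 3 kept, replacing cyclohexyl with (oxan-4-yl)methyl on a carbonyl carbon gives an 8.1-fold higher number from compound 3 to compound 4 (0.91 log units; beyond the scatter) in this assay and shows that this position responds to a change between two non-aromatic six-membered rings, not only to the exchange of phenyl for cyclohexyl already on record. Measured against the benzoyl compound, the same position gives a 58-fold higher number from compound 2 to compound 4 (1.76 log units; beyond the scatter) and so covers a large part of the range seen in the series without any change outside the acyl group. An acylated ring nitrogen can also carry a number level with that of the compound bearing oxan-4-yl directly on the amine nitrogen, as a 1.4-fold lower number from compound 1 to compound 4 (0.15 log units; within the scatter) shows, although compound 2 and compound 3 go against reading this as a general feature of the acyl compounds.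

As far as these compounds go, the step from compound 3 to compound 4 brings in both a ring oxygen and an extra carbon, so it remains open which of them goes with the rise, a question that cyclohexylmethyl or oxan-4-yl on the carbonyl carbon would address, and how an amine or a carboxylic acid on the acyl chain would read. No measurement is at hand that bears on the cause of these steps.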